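Benzyl Ring Swaps on a Nucleoside Transporter Inhibitor Series

A few compounds are considered here, and "the series" means these few. Any claim that something is new, unique, unknown or untested is made for them only; others in the source may bear on it.

Compound 1, `OC[C@H]1O[C@@H](n2cnc3c(SCc4ccccc4Cl)ncnc32)[C@H](O)[C@@H]1O`: in an assay on isolated protein for inhibition of Equilibrative nucleoside transporter 1 (Homo sapiens) (a higher number here means a weaker inhibitor, a lower number a stronger inhibitor), compound 1 gives 117 nM.
Compound 2, `N#Cc1ccc(CSc2ncnc3c2ncn3[C@@H]2O[C@H](CO)[C@@H](O)[C@H]2O)cc1`: in this assay compound 2 gives 4.57 nM.
Compound 3, `OC[C@H]1O[C@@H](n2cnc3c(SCc4ccc(Cl)c(Cl)c4)ncnc32)[C@H](O)[C@@H]1O`: in this assay compound 3 gives 12.6 nM.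

Compound 3 stands second highest of the three numbers. Its nearest neighbour is compound 2, reached by the step of a 2.8-fold higher number from compound 2 to compound 3 (0.44 log units; beyond the scatter), and its furthest is compound 1, as the step of a 9.3-fold lower number from compound 1 to compound 3 (0.97 log units; beyond the scatter) shows. Compound 4, `Cc1cc(C)c(CSc2ncnc3c2ncn3[C@@H]2O[C@H](CO)[C@@H](O)[C@H]2O)c(C)c1`, differs from compound 3 in one place: 2,4,6-trimethylphenyl in place of 3,4-dichlorophenyl on a saturated chain carbon bound to a sulfur. For the measured compounds named here, the steps that bear on this change are those that alter the same ring at the same place: a 26-fold lower number from compound 1 to compound 2 (1.41 log units; beyond the scatter) was large, a 9.3-fold lower number from compound 1 to compound 3 (0.97 log units; beyond the scatter) was modest, and a 2.8-fold higher number from compound 2 to compound 3 (0.44 log units; beyond the scatter) was modest. Each of them moved the number beyond the scatter, so a further ring swap here is expected to do so as well. Going by the values given here, no measured compound carries a methyl group on this ring, so the direction is uncertain; the estimate for compound 4 leans toward a modest step to a higher number, a 2.8-fold higher number from compound 3 to compound 4 (0.44 log units; beyond the scatter). Compound 4 is therefore estimated at 35 nM in this assay, with a range from 9 nM to 140 nM.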

Compound 4, inhibition constant: 1910 nM
Beside the measured number, compound 4's estimate is 55-fold (1.74 log units) below it; measured number outside the range, above it.
By their numbers in this assay, from the lowest: compound 2; then compound 3; then compound 1; then compound 4.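

In this assay this position proves able to move the number in the other direction: compound 2 and compound 3 both lie below compound 1, whereas the 2,4,6-trimethylphenyl ring gives a 16-fold higher number from compound 1 to compound 4 (1.21 log units; beyond the scatter), which makes compound 4 the weakest inhibitor of the four. The swap of the 3,4-dichlorophenyl ring gives a 150-fold higher number from compound 3 to compound 4 (2.18 log units; beyond the scatter), and the swap of the 4-cyanophenyl ring gives a 420-fold higher number from compound 2 to compound 4 (2.62 log units; beyond the scatter), both larger than the widest earlier step, a 26-fold lower number from compound 1 to compound 2 (1.41 log units; beyond the scatter), so the benzyl ring on the saturated chain carbon bound to a sulfur governs a much wider span of values than the first three compounds revealed. No supporting data are available to explain why the 2,4,6-trimethylphenyl ring raises the number so sharply.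

As far as these compounds go, whether a single methyl group on this ring would raise the number in the same way, or whether all three are needed, remains open, as does the effect of the chlorine atoms that leave with the 3,4-dichlorophenyl ring. From the compounds shown here alone, how a methoxy group or an amine on the same ring would behave also remains open.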